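A few compounds are considered here, and "the series" means these few. Any claim that something is new, unique, unknown or untested is made for them only; others in the source may bear on it.

The measured compounds:
- compound 1 `Cc1cc2ccccc2nc1-c1cn(CCC(F)(F)C(F)(F)C(F)(F)C(F)(F)C(F)(F)C(F)(F)C(F)(F)C(F)(F)F)nn1`: 56.6 ug/mL
- compound 2 `CCCCCCCCCCn1cc(-c2nc3ccccc3cc2CC)nn1`: 12.7 ug/mL
- compound 3 `CCCCCc1cc2ccccc2nc1-c1cn(CCC(F)(F)C(F)(F)C(F)(F)C(F)(F)C(F)(F)C(F)(F)C(F)(F)C(F)(F)F)nn1`: a limit only, > 100 ug/mL

All three were tested in a functional assay on U-937 cells (Homo sapiens) for cytotoxicity, read by MTT assay, with a stated time of 24 h; on this read-out lower numbers stand for stronger inhibition and higher numbers for weaker inhibition. Compound 1 gives 56.6 ug/mL. Among the measured compounds shown here, compound 2, which carries a different long chain on the other side of the shared core, gives 12.7 ug/mL; no single-point step connects it to the others, so its value stands on its own. Compound 3 reaches the limit of this assay: its entry, > 100 ug/mL, is not a number but a boundary, and where compound 3 truly stands is known only as the limit of > 100 ug/mL in this assay, at which 1 of the 3 values shown sits. For the measured compounds named here, the one measured step that touches compound 3 is an at least 1.7-fold higher number from compound 1 to compound 3 (0.24 log units; that floor lies within the scatter), a change whose floor lies within scatter, so it may be small or large.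

Compound 4 `CCCc1cc2ccccc2nc1-c1cn(CCC(F)(F)C(F)(F)C(F)(F)C(F)(F)C(F)(F)C(F)(F)C(F)(F)C(F)(F)F)nn1` differs from compound 3 by hydrogen in place of ethyl on a saturated chain carbon, three bonds along the chain from an aromatic carbon. Its chain is thus shorter than that of compound 3 and longer than that of compound 1, so compound 4 is expected to fall between those two, with a step of an at least 1.3-fold lower number from compound 3 to compound 4 (0.12 log units; that floor lies within the scatter) toward a lower number that may well stay within scatter. Compound 4 is estimated at 75 ug/mL, with a range from 35 ug/mL to 150 ug/mL.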

Compound 4, half-maximal inhibitory concentration: > 100 ug/mL
Compound 4: only a limit was reported (the forecaster's own chance of this, stated with the estimate: 35%); middle value at least 1.3-fold (0.12 log units) away from the limit.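

In this assay compound 4 also gives only a limit of the assay, > 100 ug/mL. The measured step, an at least 1.7-fold higher number from compound 1 to compound 4 (0.24 log units; that floor lies within the scatter), shows that the propyl group of compound 4, like the pentyl group of compound 3, leaves the read-out without a number, whereas the methyl group of compound 1 gives one; with its floor inside the scatter, however, this step may be small or large. Shortening pentyl to propyl therefore does not bring the value back into the readable range, and the step from compound 3 to compound 4 cannot be read, because both compounds rest on the same boundary: the limit of > 100 ug/mL in this assay, at which 2 of the 4 values shown sit.

Still open, as far as these compounds go, is how far compound 3 and compound 4 truly lie past the limit, and where along the way from methyl to propyl the value reaches it, a question that an ethyl group on the shared core with the long chain of compound 1 would address. Also open, from the compounds shown here alone, is how an amine or a carboxylic acid in that same place would read.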